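A few compounds are considered here, and "the series" means these few. Any claim that something is new, unique, unknown or untested is made for them only; others in the source may bear on it.

Of the compounds shown here, three have been measured in a functional assay on MIA PaCa-2 cells (Homo sapiens) for inhibition, read by MTT assay, with a stated time of 7 days; a lower number here means a stronger inhibitor, a higher number a weaker inhibitor. For the measured compounds named here, compound 1 `O=C([C@@H]1CCCN(S(=O)(=O)c2ccc(S(=O)(=O)C3CCC3)cc2)C1)N1CCC(F)(F)CC1` gives 9 nM, and compound 2 `CCC(CC)S(=O)(=O)c1ccc(S(=O)(=O)N2CCC[C@@H](C(=O)N3CCC(F)(F)CC3)C2)cc1` gives 13 nM; the only single-point step among them, a 1.4-fold higher number from compound 1 to compound 2 (0.16 log units; within the scatter), changes a substituent on a sulfonyl sulfur far from the amide end. Compound 3 `CCN(CC)S(=O)(=O)c1ccc(S(=O)(=O)N2CCC[C@@H](C(=O)N3CCOCC3)C2)cc1` gives 350 nM, the highest of the three numbers, well beyond the scatter from compounds 1 and 2; it differs from both in more than one place, so no single step accounts for that gap.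

Compound 4 `CCN(CC)S(=O)(=O)c1ccc(S(=O)(=O)N2CCC[C@@H](C(=O)N[C@H]3CCOC3)C2)cc1` is the next step: (oxolan-3-yl)amino in place of morpholin-4-yl on a carbonyl carbon. Going by the values given here, no measured step touches the carbonyl end of the molecule, so the step from compound 1 to compound 2 says nothing about how this change will read, and there is no basis in the data for a confident direction. The estimate for compound 4 is 500 nM, with a range of 100 nM to 3000 nM. The expected step is therefore a 1.4-fold higher number from compound 3 to compound 4 (0.15 log units; within the scatter), meaning no confident change beyond the scatter, with wide uncertainty in either direction.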

Compound 4, half-maximal inhibitory concentration: 1670 nM
Estimate against measurement, compound 4: 3.3-fold (0.52 log units) below; the range from low to high includes it.
By their numbers in this assay, from the lowest: compounds 1 and 2 (each within the scatter of the next); then compound 3; then compound 4.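

For the compounds shown here, this is the first measured change at the carbonyl end of the molecule, and in this assay it is a clear one: a 4.8-fold higher number from compound 3 to compound 4 (0.68 log units; beyond the scatter). The two groups have the same heavy atoms joined differently, so this position responds to how those atoms are arranged, not only to which atoms are present. The entering (oxolan-3-yl)amino group brings a five-membered ring, a hydrogen-bond donor and a defined stereocentre all at once, and nothing available explains why the number rises.

This single step cannot show which of those three differences matters. A methyl(oxolan-3-yl)amino group, which has no amide hydrogen, or a tetrahydropyran-4-ylamino group, with a six-membered ring and the amide hydrogen kept, would begin to pull them apart.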